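The compounds below may be only part of what the source reports. "The series", "measured", "known", "first", "only" and "open" are said of these compounds alone.

Three compounds were measured in an ADME assay on L1210/0 cells (Mus musculus) for cytotoxicity, with a stated time of 48 h; a lower number here means a stronger inhibitor, a higher number a weaker inhibitor. Compound 1 `Nc1ncnc2c1ncn2C[C@@H]1C[C@H](O)c2ccccc21` gave only a limit of the assay, > 200000 nM. Compound 3 `O[C@H]1C[C@@H](Cn2cnc3c(Cl)ncnc32)c2ccccc21` likewise gave only a limit, > 200000 nM. Within the data shown here, compound 2 `Nc1nc(Cl)c2nnn([C@H]3CCCC[C@H]3CO)c2n1` is the single compound with a number: in this assay compound 2 gave 95500 nM. The difference between the core of compound 2 and the core of compound 3 is not broken down here.

The change from compound 3 to compound 1 is amino in place of chloro on an aromatic carbon, and its step in this assay is a step that the two limits leave unreadable from compound 3 to compound 1, a size that cannot be read because of the limit of > 200000 nM in this assay, at which 2 of the 3 values shown sit. Compound 4 `Nc1nc(N)c2nnn([C@H]3CCCC[C@H]3CO)c2n1`, not yet measured, arises from compound 2 by amino in place of chloro on an aromatic carbon. This is the same kind of change as that from compound 3 to compound 1, though not the same: in compound 4 the place is also meta to an amino group (1 heavy atom), which the place in compound 1 is not.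

Among the measured compounds shown here, since the only earlier instance of this change is unreadable, the expectation for compound 4 rests on compound 2 alone, whose value in this assay is 95500 nM. Compound 4 is therefore expected to stay weak, with an estimated step of a 1.6-fold higher number from compound 2 to compound 4 (0.20 log units; within the scatter) in this assay. The estimate for compound 4 in this assay is 150000 nM, expected to lie between 40000 nM and 400000 nM.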

Compound 4, half-maximal inhibitory concentration: > 200000 nM
Compound 4 was reported as a limit; the forecaster's own chance of this, stated with the estimate: 50%; middle value at least 1.3-fold (0.12 log units) from the limit.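

In this assay, as far as these compounds go, amino in place of chloro on an aromatic carbon gives an at least 2.0-fold higher number from compound 2 to compound 4 (0.32 log units; beyond the scatter), so on the core of compound 2 the change moves the number upward, and as compound 4 is reported only as a limit, the true size of the step remains open on its upper side. The same change on the other core gives no comparison, and the step from compound 3 to compound 1 cannot be read, because both compounds stand at the same limit: the limit of > 200000 nM in this assay, at which 3 of the 4 values shown sit. The result therefore shows the change on one core only; it does not show that the step carries over from one core to another, and in compound 4 the place is also meta to an amino group, which the place in compound 1 is not.

The compounds shown leave open how a methylamino, methoxy or hydroxyl group at this place on the core of compound 2 would compare with chloro and amino. They also leave open how large the change from chloro to amino is on any core where both partners give a number rather than a limit.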